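The source may hold more compounds than are shown below. What is called first, only, known or untested is meant among the compounds shown, and "the series" means these compounds.

Compound 1 `CC(C)=CCC1Cc2c(OCCCNC(=O)c3ccc([N+](=O)[O-])cc3)cc(=O)n(CCCO)c2CC1(C)C` gives 49.9% in a functional assay on PANC-1 cells (Homo sapiens) for inhibition, read by MTT assay, with a stated time of 24 h, tested at 10 uM; a higher number here means more inhibition at the concentration tested (going by the name of the read-out), a lower number less inhibition. Compound 2 `CC(C)=CCC1Cc2c(OCCCOc3ccc(Cl)cc3)cc(=O)n(CCCO)c2CC1(C)C` gives 22.7%. Compound 3 `CC(C)=CCC1Cc2c(OCCCOc3ccc([N+](=O)[O-])cc3)cc(=O)n(CCCO)c2CC1(C)C` gives 47.5%.

Compound 3 stands second highest of the three numbers. Its nearest neighbour is compound 1: a number 2.4 percentage points lower from compound 1 to compound 3 (within the scatter). Its furthest is compound 2: a number 24.8 percentage points higher from compound 2 to compound 3 (beyond the scatter). Compound 4 `CC(C)=CCC/C(C)=C/CC1Cc2c(OCCCOc3ccc([N+](=O)[O-])cc3)cc(=O)n(CCCO)c2CC1(C)C` differs from compound 3 in one place: 3-methylbut-2-en-1-yl in place of hydrogen on a saturated chain carbon bound to a double-bonded chain carbon. Among the measured compounds shown here, none of the measured steps touches this group; each of them changes another part of the molecule, so no measured step bears on this change, and its size cannot be read from the data. With nothing to anchor a shift, the expectation is no step beyond the scatter, namely a number 0.5 percentage points higher from compound 3 to compound 4 (within the scatter). Compound 4 is therefore estimated at 48%, with a range from 30% to 65%.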

Compound 4, a percentage reported as inhibition, at one concentration (the size of the read-out at that concentration, not a potency): 65.1%
Estimate against measurement, compound 4: 17.1 percentage points below; measured number above the stated range.
By their numbers in this assay, from the lowest: compound 2; then compounds 3 and 1 (each within the scatter of the next); then compound 4.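

In this assay, adding 3-methylbut-2-en-1-yl on a saturated chain carbon bound to a double-bonded chain carbon turns the 3-methylbut-2-en-1-yl side chain into 3,7-dimethylocta-2,6-dien-1-yl, and the result is a number 17.6 percentage points higher from compound 3 to compound 4 (beyond the scatter). Among the compounds shown here, the earlier compounds all carry the shorter chain, so only this step shows that this part of the molecule, and not just the other end, can move the read-out. Nothing measured here explains the shift.

On these data alone, whether a longer chain, or a saturated chain of the same length, would give the same rise stays open. So does the effect of an amine or a carboxylic acid at the end of this chain, and whether the extension would act alike on compound 1 or compound 2.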